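The compounds below may be only part of what the source reports. "The series", "measured", "known", "first", "only" and "open" are said of these compounds alone.

In a functional assay on CCRF-CEM cells (Homo sapiens) for antiproliferative activity, read by fluorescence and resazurin assay, with a stated time of 48 h (a lower number here means a stronger inhibitor, a higher number a weaker inhibitor), compound 1 `CCOc1ccc(NC(=O)c2cc3cc(Br)ccc3oc2=O)cc1` gives 21800 nM. Compound 3 `CCOc1ccc2nc(Cl)c(/C=N/NC(=O)c3cc4cc(Br)ccc4oc3=O)cc2c1` gives 12900 nM, which is within the scatter of compound 1. Compound 2 `O=C(N/N=C/c1ccncc1)c1cc2cc(Br)ccc2oc1=O` gives 6340 nM, a lower number than compound 1 by more than the scatter. Compound 1 thus sits at the weak end of this small set, level with compound 3. Compound 4 `CCOc1ccc(NC(=O)c2cc3cc([N+](=O)[O-])ccc3oc2=O)cc1` differs from compound 1 in one place: nitro in place of bromo on an aromatic carbon. It carries nitro in place of bromo on an aromatic carbon. Going by the values given here, no measured pair here shows this exchange, so no step beyond the scatter is expected in this assay. The expected change is a 1.3-fold lower number from compound 1 to compound 4 (0.11 log units; within the scatter), a slightly lower number at most. For compound 4 the estimated value is 17000 nM, with an expected range of 6000 nM to 45000 nM.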

Compound 4, half-maximal inhibitory concentration: 13200 nM
The estimate for compound 4 lay 1.3-fold (0.11 log units) above the measured number; the measured number falls inside the stated range.
By their numbers in this assay, from the lowest: compound 2; then compounds 3, 4 and 1 (each within the scatter of the next).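

In this assay, nitro in place of bromo on this aromatic carbon gives a 1.7-fold lower number from compound 1 to compound 4 (0.22 log units; within the scatter) and so shows that, at this position of the shared core, three heavy atoms can replace one without a step beyond the scatter. The earlier compounds shown here held bromo here throughout and could not show this. No available evidence accounts for this result. As far as these compounds go, an amine, a methoxy group or plain hydrogen at this carbon remains open, as does whether this exchange would read the same in compound 2 or compound 3.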